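Swapping a fluorinated ring for an aminomethyl ring

The source may hold more compounds than are shown below. What is called first, only, known or untested is meant among the compounds shown, and "the series" means these compounds.

Of the compounds shown here, three built on one shared core have been tested in an assay on isolated protein for inhibition of Rho-associated protein kinase 2 (Homo sapiens), read by scintillation counting, radiometric assay and 33P incorporation, with a stated time of 40 min, in the presence of a further agent that is not named here; on this read-out lower numbers stand for stronger inhibition and higher numbers for weaker inhibition. Compound 1 `CCc1ccc(C(=O)Nc2cccc(NC(=O)COc3ccc4c(=O)ccoc4c3)c2)cc1` gives 24 nM. Compound 2 `N#Cc1ccc(C(=O)Nc2cccc(NC(=O)COc3ccc4c(=O)ccoc4c3)c2)cc1` gives 15 nM. Compound 3 `Cc1cc(C(=O)Nc2cccc(NC(=O)COc3ccc4c(=O)ccoc4c3)c2)ccc1C(F)(F)F` gives 43 nM, the largest of the three numbers, though one of the steps leading to it, a 1.8-fold higher number from compound 1 to compound 3 (0.25 log units; within the scatter), lies within the scatter and only the other, a 2.9-fold higher number from compound 2 to compound 3 (0.46 log units; beyond the scatter), lies beyond it.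

Compound 4 `NCc1ccc(C(=O)Nc2cccc(NC(=O)COc3ccc4c(=O)ccoc4c3)c2)cc1` differs from compound 3 in one place: a group of 8 heavy atoms (7 carbon, 1 nitrogen; one six-membered aromatic ring of carbon only) in place of a group of 11 heavy atoms (8 carbon, 3 fluorine; one six-membered aromatic ring of carbon only), on a carbonyl carbon. For the measured compounds named here, the steps that bear on this change are the two that, read backwards, remove the same fluorinated group in favour of a ring carrying a single substituent: a 1.8-fold higher number from compound 1 to compound 3 (0.25 log units; within the scatter) and a 2.9-fold higher number from compound 2 to compound 3 (0.46 log units; beyond the scatter). Both point toward a lower number once that group is gone, one within the scatter and one modestly beyond it. Going by the values given here, no measured compound carries an aminomethyl group, so the size remains uncertain. A modest fall in this assay is therefore expected, a 2.2-fold lower number from compound 3 to compound 4 (0.33 log units; beyond the scatter), and compound 4 is estimated at 20 nM, within a range from 6 nM to 70 nM.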

Compound 4, half-maximal inhibitory concentration: 66 nM
Beside the measured number, compound 4's estimate is 3.3-fold (0.52 log units) below it; the range from low to high includes it.
By their numbers in this assay, from the lowest: compounds 2, 1, 3 and 4 (each within the scatter of the next, the first and the last beyond it).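

Exchanging the fluorinated ring for 4-(aminomethyl)phenyl gives a 1.5-fold higher number from compound 3 to compound 4 (0.19 log units; within the scatter), so this assay does not tell these two groups apart, and losing the fluorinated ring does not by itself bring the lower numbers of compounds 1 and 2. The single substituent on the ring still counts: aminomethyl in place of nitrile gives a 4.4-fold higher number from compound 2 to compound 4 (0.64 log units; beyond the scatter), and even amino in place of the methyl at the end of the ethyl chain gives a 2.8-fold higher number from compound 1 to compound 4 (0.44 log units; beyond the scatter). Nothing available here explains these steps.

From the compounds shown here alone, it remains open whether a longer chain ending in an amine, or a carboxylic acid in place of aminomethyl, would read closer to compound 2 or to compound 4. Going by these compounds, how a ring carrying trifluoromethyl alone, without the methyl of compound 3, would read also stays unknown.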